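Swapping Phenyl for Propyl on the Saturated Chain

A few compounds are considered here, and "the series" means these few. Any claim that something is new, unique, unknown or untested is made for them only; others in the source may bear on it.

Of the compounds shown here, three with a shared core have been tested in an assay on isolated protein for inhibition of Dihydrofolate reductase (Homo sapiens), read by spectrophotometry; on this read-out higher numbers stand for weaker inhibition and lower numbers for stronger inhibition. Compound 1 `CC1=Nc2c(O)nc(N)nc2OC1c1ccccc1` gives 740000 nM. Compound 2 `Nc1nc(O)c2c(n1)OCC(Cc1ccccc1)=N2` gives 28000 nM in this assay. Compound 3 `Nc1nc(O)c2c(n1)OCC(CCc1ccccc1)=N2` gives 3000 nM, the lowest of the three numbers, and its distance to both others lies beyond the scatter. Compound 4 `CCCCCC1=Nc2c(O)nc(N)nc2OC1` has not yet been measured. It differs from compound 3 in one place: propyl in place of phenyl on a saturated chain carbon, two bonds along the chain from a carbon with a double bond to nitrogen. Within the data shown here, no pair of measured compounds shows this kind of change, so the expectation rests on the three numbers alone. The step is expected to go toward weaker inhibition, beyond the scatter, at about a 4.0-fold higher number from compound 3 to compound 4 (0.60 log units; beyond the scatter). Compound 4 is therefore estimated at 12000 nM, with a range from 3000 nM to 50000 nM.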

Compound 4, half-maximal inhibitory concentration: 11000 nM
For compound 4 the middle estimate is 1.1-fold (0.04 log units) above the measured one; low and high end bracket the measured number.
By their numbers in this assay, from the lowest: compound 3; then compound 4; then compound 2; then compound 1.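

In this assay, propyl in place of phenyl on a saturated chain carbon, two bonds along the chain from a carbon with a double bond to nitrogen, gives a 3.7-fold higher number from compound 3 to compound 4 (0.56 log units; beyond the scatter), so inhibition weakens but survives without the ring. Butyl in place of phenyl on a saturated chain carbon bound to a carbon with a double bond to nitrogen gives a 2.5-fold lower number from compound 2 to compound 4 (0.41 log units; beyond the scatter), placing the ring-free compound 4 between the two phenyl compounds. Nothing shown here explains either step. From the compounds shown here alone, how a longer chain, or an amine or carboxylic acid at the chain end, would compare with compound 3 remains open.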